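The source may hold more compounds than are shown below. What is called first, only, known or untested is meant among the compounds shown, and "the series" means these compounds.

Compound 1 `CCCCCOC1(c2ccc(Cl)cc2)SC=C(C)n2c1noc2=O` was tested in a functional assay on A2780 cells (Homo sapiens) for antiproliferative activity, read by MTT assay, with a stated time of 3 days; on this read-out lower numbers stand for stronger inhibition and higher numbers for weaker inhibition. In this assay compound 1 gives only a limit, > 100000 nM, and no number. Compound 2 `CC1=CSC(O)(c2ccccc2)c2noc(=O)n21` shares the same core. In this assay compound 2 likewise gives only a limit, > 100000 nM. Both values sit at one and the same place: the limit of > 100000 nM in this assay, at which 2 of the 2 values shown sit. So compound 1 stands where every value shown stands, with nothing beneath the limit to rank it against.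

Compound 3 `CCCCCCCCCCCCCCCOC1(c2ccc(Cl)cc2)SC=C(C)n2c1noc2=O` differs from compound 1 in one place: decyl in place of hydrogen on a saturated chain carbon, five bonds along the chain from an oxygen on a saturated carbon. For the measured compounds named here, no measured step between two compounds is available here, so the expected step, a number no higher from compound 1 to compound 3 (the limit leaves the size open), is none beyond the scatter. For compound 3 the estimate in this assay is 100000 nM, with a range from 30000 nM to 300000 nM, and the most likely outcome is expected to be a limit again rather than a number.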

Compound 3, half-maximal inhibitory concentration: > 100000 nM
Compound 3 ended at the assay's limit (the forecaster's own chance of this, stated with the estimate: 85%); the middle value sits exactly at the limit.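

In this assay compound 3 gives only a limit, as compound 1 does, so no step can be read between compound 1 and compound 3. Left open is whether any change to the shared core or its chain brings a real number, as all values so far share one place: the limit of > 100000 nM in this assay, at which 3 of the 3 values shown sit.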